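The compounds below may be only part of what the source reports. "The series", "measured", "known", "first", "only" and "open" are said of these compounds alone.

In a functional assay on T98G cells (Homo sapiens) for inhibition, read by colorimetric assay and MTT assay, with a stated time of 72 h (a higher number here means a weaker inhibitor, a lower number a stronger inhibitor), three compounds have been measured so far. Compound 1 `Cn1c2cnc1OCCCCCCCCOc1cc(F)ccc1-2` gives 69000 nM, and compound 2 `Cn1c2cnc1OCCCCCCCCCCOc1ccccc1-2` gives 41000 nM. Compound 3 `C=CCCCCOc1ccccc1-c1cnc(OCCC=C)n1C` gives 29000 nM, which lies within the scatter of compound 2 and is beyond the scatter on the stronger side of compound 1.

Compound 4 `C=CCCCCOc1ccc(C)cc1-c1cnc(OCCC=C)n1C` differs from compound 3 in one place: methyl in place of hydrogen on an aromatic carbon, para to a (hex-5-en-1-yl)oxy group. For the measured compounds named here, no two measured compounds differ in only one place, so the data offer no direct precedent for this change. The measured numbers span only a narrow range, from compound 3 at 29000 nM to compound 1 at 69000 nM, so a small step is expected, with no clear direction and probably none beyond the scatter. The expected change is a 1.0-fold higher number from compound 3 to compound 4 (0.01 log units; within the scatter). For compound 4, the estimated value is 30000 nM, with an expected range from 14000 nM to 65000 nM.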

Compound 4, half-maximal inhibitory concentration: 94000 nM
Beside the measured number, compound 4's estimate is 3.1-fold (0.50 log units) below it, and the stated range ends below it.
By their numbers in this assay, from the lowest: compounds 3, 2, 1 and 4 (each within the scatter of the next, the first and the last beyond it).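

In this assay, for the compounds shown here, this is the first change in one place that can be read, and it shows that the position para to the (hex-5-en-1-yl)oxy group does not tolerate every substituent without consequence. Methyl in place of hydrogen gives a 3.2-fold higher number from compound 3 to compound 4 (0.51 log units; beyond the scatter), a modest step toward a weaker inhibitor. The earlier compounds shown here offered no pair from which the effect of any substitution could be read, so this single step now gives the position a direction, though for methyl alone. Nothing in the data shown accounts for the step.

As far as these compounds go, whether fluorine, methoxy or a longer chain such as ethyl at this same position would follow methyl remains open. Also open, from the compounds shown here alone, is whether methyl would give a step of similar size on the core of compound 2.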